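Chain length and cytotoxicity across the shared core

The source may report more compounds than this note shows. Statements on the series, on what has been measured and on what is new or still open speak of the compounds shown alone.

Measured so far in an ADME assay on L929 cells (Mus musculus, culture collection number NCTC 929) for cytotoxicity, read by MTT assay, with a stated time of 72 h; a lower number here means a stronger inhibitor, a higher number a weaker inhibitor:
compound 1 `Cc1cc(O)c(CC2CCCCC2)c(=O)o1`, > 200000 nM
compound 2 `CCCCCCCCCCCCCC(=O)c1c(O)cc(C)oc1=O`, > 200000 nM
compound 3 `CCCCCCCCCCCCCCCC(=O)c1c(O)cc(C)oc1=O`, 165000 nM

Compound 1 reaches only the assay limit, > 200000 nM, in this assay. Compound 2 likewise gives only the limit, > 200000 nM, and not a number. Compound 3 alone yields a number, 165000 nM. Going by the values given here, the single step between neighbours, an at least 1.2-fold lower number from compound 2 to compound 3 (0.08 log units; that floor lies within the scatter), lies inside the scatter, and the series as a whole is characterised by the limit of > 200000 nM in this assay, at which 2 of the 3 values shown sit.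

Compound 4, `CCCCCC(=O)c1c(O)cc(C)oc1=O`, has not yet been measured in this assay. Against compound 2 the difference is hydrogen in place of octyl on a saturated chain carbon, five bonds along the chain from a carbonyl carbon. Among the compounds with values here, no measured step covers a shortening of this kind; the only step available is the one above, which is itself within the scatter and concerns the far end of the chain. Nothing in the data therefore points to a shift beyond the scatter in either direction. Compound 4 is expected to sit around 250000 nM, within 100000 nM to 600000 nM, with a fair chance that this assay again returns only a limit. The expected step, a step that the limit leaves unreadable from compound 2 to compound 4, is thus estimated as none beyond the scatter.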

Compound 4, half-maximal inhibitory concentration: > 200000 nM
Compound 4 gave a limit, no number; the forecaster's own chance of this, stated with the estimate: 70%; the middle value lies beyond the limit too.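

Compound 4 gives only a limit, > 200000 nM, and compound 2 also stands at a limit, so no step can be read between compound 2 and compound 4. Left open is whether hydrogen in place of octyl changes cytotoxicity at all, with the series resting on: the limit of > 200000 nM in this assay, at which 3 of the 4 values shown sit.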